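The source may hold more compounds than are shown below. What is called first, only, known or untested is meant among the compounds shown, and "the series" means these compounds.

Measured in a functional assay on SK-OV-3 cells (Homo sapiens) for cytotoxicity, read by spectrophotometry, with a stated time of 72 h; a lower number here means a stronger inhibitor, a higher number a weaker inhibitor:
- compound 1 `COc1ccc(-c2cccc(=O)n2-c2cc(OC)c(OC)c(OC)c2)cc1O`: < 10 nM (a limit of the assay)
- compound 2 `COc1cc(-n2c(-c3ccncc3)cccc2=O)cc(OC)c1OC`: 1790 nM

Going by the values given here, compound 2, at 1790 nM, holds the only actual number so far in this assay. The other result is the limit of < 10 nM in this assay, at which 1 of the 2 values shown sits, reached by compound 1 and not a number. Compound 3 `COc1ccc(-c2cccc(=O)n2-c2cc(OC)c(OC)c(OC)c2)cc1C` carries 4-methoxy-3-methylphenyl in place of pyridin-4-yl on an aromatic carbon, next to the ring nitrogen: 4-methoxy-3-methylphenyl in place of pyridin-4-yl on an aromatic carbon. Among the compounds with values here, one measured step bears on this site, an at least 170-fold higher number from compound 1 to compound 2 (2.25 log units; beyond the scatter), which is large and beyond the scatter. It put pyridin-4-yl in place of the 3-hydroxy-4-methoxyphenyl of compound 1. Compound 3 brings back a methoxy-bearing phenyl group, so much of that loss is expected to reverse, towards a lower number and a stronger inhibitor. The expected step is large: a 72-fold lower number from compound 2 to compound 3 (1.85 log units; beyond the scatter). The estimate for compound 3 is 25 nM, within an expected range of 4 nM to 200 nM.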

Compound 3, half-maximal inhibitory concentration: 583 nM
Compound 3: the middle estimate sits 23-fold (1.37 log units) below what was measured; the measured number lies above the stated range.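

In this assay, on an aromatic carbon next to the ring nitrogen, 4-methoxy-3-methylphenyl in place of pyridin-4-yl gives only a 3.1-fold lower number from compound 2 to compound 3 (0.49 log units; beyond the scatter), so a methoxy-bearing phenyl group alone does not bring back the strength of compound 1. The larger part of the difference follows a single swap on that phenyl group, methyl in place of hydroxy, which gives an at least 58-fold higher number from compound 1 to compound 3 (1.76 log units; beyond the scatter). The size of this step has no upper end, as compound 1 gives a limit of the assay and not a number: the limit of < 10 nM in this assay, at which 1 of the 3 values shown sits.

What the compounds shown leave open is whether an amine or a fluorine in place of that hydroxy would keep the strength of compound 1. They also leave open how far the number would rise if the hydroxy were moved elsewhere on the phenyl group.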